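The compounds below may be only part of what the source reports. "The series", "measured", "known", "first", "only" and "open" are said of these compounds alone.

Measured so far in a functional assay on PC-3 cells (Homo sapiens) for antiproliferative activity, read by WST assay, with a stated time of 72 h; a higher number here means a weaker inhibitor of growth, a lower number a stronger inhibitor of growth:
- compound 1 `C#Cc1ccc(N/N=N/c2ccc(C(=N)N)cc2)cc1`: 22500 nM
- compound 2 `N=C(N)c1ccc(/N=N/Nc2cccc(C#Cc3ccc(F)cc3)c2)cc1`: 5300 nM
- compound 3 `COc1ccc(C#Cc2cccc(N/N=N/c3ccc(C(=N)N)cc3)c2)cc1`: 5000 nM

Compound 3 carries the lowest of the three numbers, but this says little: compound 2 sits within the scatter of it, and only compound 1 lies clearly apart, with a higher number in this assay. Going by the values given here, for compound 1 no single-point step to either other compound is defined, so only the two values themselves can be compared.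

The next compound, compound 4 `N=C(N)c1ccc(/N=N/Nc2cccc(C#Cc3ccccc3)c2)cc1`, differs from compound 3 in one place: hydrogen in place of methoxy on an aromatic carbon. Among the compounds with values here, the only measured step that bears on this site is a 1.1-fold lower number from compound 2 to compound 3 (0.03 log units; within the scatter), which exchanged one small substituent for another at the same aromatic carbon without moving the number beyond the scatter. Nothing else in the data speaks to this position.

On that basis a change of a 1.1-fold higher number from compound 3 to compound 4 (0.04 log units; within the scatter) is expected, that is, no step beyond the scatter in this assay. Compound 4 is estimated at 5500 nM, with a range of 2500 nM to 12000 nM.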

Compound 4, concentration for 50% growth inhibition: 5800 nM
Compound 4: the middle estimate sits 1.1-fold (0.02 log units) below what was measured, within the range that was stated.
By their numbers in this assay, from the lowest: compounds 3, 2 and 4 (each within the scatter of the next); then compound 1.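

Taking the substituent off altogether, 4-methoxyphenyl to phenyl, moves nothing beyond the scatter in this assay (a 1.2-fold higher number from compound 3 to compound 4 (0.06 log units; within the scatter)), and hydrogen in place of fluoro reads the same (a 1.1-fold higher number from compound 2 to compound 4 (0.04 log units; within the scatter)). Compound 2, compound 3 and compound 4 thus form a set of three, with fluoro, methoxy and hydrogen on this aromatic carbon, para to a large group, all within the scatter of each other; the earlier exchange of one small substituent for another now extends to having no substituent at all. No measurement at hand accounts for this flat result.

Still open, on these data alone, is whether an amine, a carboxylic acid or a longer chain such as butoxy on this carbon would move the number beyond the scatter. The three substituents shown cover only small groups, so how far this tolerance reaches in the series remains unknown.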